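Replacing pyrimidin-2-yl on the sulfur of compound 3

The source may hold more compounds than are shown below. What is called first, only, known or untested is meant among the compounds shown, and "the series" means these compounds.

In a functional assay on MCF7 cells (Homo sapiens) for inhibition, read by MTT assay, with a stated time of 72 h (a lower number here means a stronger inhibitor, a higher number a weaker inhibitor), compound 1 `FC(F)(F)c1ccc(CSc2nc(N3CCNCC3)cc(C(F)(F)F)n2)cc1` gives 10700 nM and compound 2 `CN1CCN(c2cc(C(F)(F)F)nc(SCc3ccc(C(F)(F)F)cc3)n2)CC1` gives 30200 nM. Compound 3 `FC(F)(F)c1ccc(CSc2nc(Sc3ncccn3)cc(C(F)(F)F)n2)cc1` gives no number, only a limit of the assay (> 50000 nM). Compound 4 `FC(F)(F)c1ccc(CSc2nc(Sc3nnnn3-c3ccccc3)cc(C(F)(F)F)n2)cc1` carries 1-phenyl-1H-tetrazol-5-yl in place of pyrimidin-2-yl on a sulfur. For the measured compounds named here, two measured steps bear on this place: (pyrimidin-2-yl)sulfanyl in place of piperazin-1-yl gave an at least 4.6-fold higher number from compound 1 to compound 3 (0.66 log units; beyond the scatter) and in place of 4-methylpiperazin-1-yl gave an at least 1.6-fold higher number from compound 2 to compound 3 (0.21 log units; that floor lies within the scatter) with its floor within the scatter. Neither changes the group on the sulfur, so no step beyond the scatter is expected in this assay (an at least 1.1-fold lower number from compound 3 to compound 4 (0.07 log units; that floor lies within the scatter)). For compound 4 the estimated value is 42000 nM (expected range 15000 nM to 80000 nM).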

Compound 4, half-maximal inhibitory concentration: 39500 nM
For compound 4 the middle estimate is 1.1-fold (0.03 log units) above the measured one; the range from low to high includes it.
By their numbers in this assay, from the lowest: compound 1; then compounds 2 and 4 (each within the scatter of the next). At a limit, above all of these: compound 3.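

Among the compounds shown, only this pair differs in the group on the sulfur, and in this assay 1-phenyl-1H-tetrazol-5-yl in place of pyrimidin-2-yl gives an at least 1.2-fold lower number from compound 3 to compound 4 (0.10 log units; that floor lies within the scatter). The group on the sulfur can therefore carry an added phenyl ring and still give a measured number. The true size of this step cannot be read, since compound 3 stands at a limit: the limit of > 50000 nM in this assay, at which 1 of the 4 values shown sits.

On these data alone, whether a tetrazole without the phenyl ring, a plain phenyl, or a carboxylic acid on this sulfur would lower the number remains open.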